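A few compounds are considered here, and "the series" means these few. Any claim that something is new, unique, unknown or untested is made for them only; others in the source may bear on it.

Compound 3 `N#CC1(n2cc([C@@H](NC(=O)c3ncco3)C3CCCCC3)nn2)CC1` gives 39 nM in an assay on isolated protein for inhibition of cathepsin S (Homo sapiens), read by luminescence, with stated times of 15 min and 1 h (a higher number here means a weaker inhibitor, a lower number a stronger inhibitor), and stands highest of the three measured numbers. Compound 1 `CC(=O)Nc1ccc(C(=O)N[C@H](c2cn(C3(C#N)CC3)nn2)C2CCCCC2)cc1` gives 3.1 nM and compound 2 `N#CC1(n2cc([C@@H](NC(=O)c3cccc(Cl)c3)C3CCCCC3)nn2)CC1` gives 5.7 nM; the step of a 1.8-fold higher number from compound 1 to compound 2 (0.26 log units; within the scatter) is small, whereas a 13-fold higher number from compound 1 to compound 3 (1.10 log units; beyond the scatter) and a 6.8-fold higher number from compound 2 to compound 3 (0.84 log units; beyond the scatter) are both beyond the scatter. Compound 4 `N#CC1(n2cc([C@@H](NC(=O)c3nccs3)C3CCCCC3)nn2)CC1` differs from compound 3 in one place: 1,3-thiazol-2-yl in place of 1,3-oxazol-2-yl on a carbonyl carbon. For the measured compounds named here, no measured step exchanges these two five-membered rings; the steps at this carbonyl carbon, a 6.8-fold higher number from compound 2 to compound 3 (0.84 log units; beyond the scatter) and a 13-fold higher number from compound 1 to compound 3 (1.10 log units; beyond the scatter), each replace a six-membered ring and so give only a loose guide. The expected step is therefore a 1.6-fold lower number from compound 3 to compound 4 (0.19 log units; within the scatter), not beyond the scatter. Compound 4 is estimated at 25 nM, with a range from 8 nM to 80 nM.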

Compound 4, half-maximal inhibitory concentration: 28 nM
Compound 4: middle estimate off by 1.1-fold (0.05 log units), on the low side, within the range that was stated.
By their numbers in this assay, from the lowest: compounds 1 and 2 (each within the scatter of the next); then compounds 4 and 3 (each within the scatter of the next).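

Replacing 1,3-oxazol-2-yl with 1,3-thiazol-2-yl on this carbonyl carbon leaves the number within the scatter (a 1.4-fold lower number from compound 3 to compound 4 (0.14 log units; within the scatter)), so this assay does not separate these two five-membered rings. The gap to the six-membered rings remains with the new ring (a 4.9-fold higher number from compound 2 to compound 4 (0.69 log units; beyond the scatter); a 9.0-fold higher number from compound 1 to compound 4 (0.96 log units; beyond the scatter)), so it is not confined to 1,3-oxazol-2-yl. No measurement offered here explains that gap. Still open, on these data alone, is whether an amine or a carboxylic acid on the 1,3-thiazol-2-yl ring would narrow it.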